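From furan-3-yl to phenyl at the assay limit

The source may hold more compounds than are shown below. What is called first, only, known or untested is meant among the compounds shown, and "the series" means these compounds.

Of the compounds shown here, three have been tested so far in an ADME assay on MRC5 cells (Homo sapiens), read by MTT assay, with a stated time of 72 h (on this read-out higher numbers stand for weaker inhibition and lower numbers for stronger inhibition), and none of them yields a true number. Compound 1 `COc1ncnc2c1c(-c1ccccc1)cn2[C@@H]1O[C@H](CO)[C@@H](O)[C@H]1O` gives > 100000 nM which is a limit of the assay and not a number. Compound 2 `CSc1ncnc2c1c(-c1ccccc1)cn2[C@@H]1O[C@H](CO)[C@@H](O)[C@H]1O` gives > 100000 nM which is also a limit. Compound 3 `CNc1ncnc2c1c(-c1ccoc1)cn2[C@@H]1O[C@H](CO)[C@@H](O)[C@H]1O` gives > 100000 nM and this too is only a limit. So compound 3 stands where the others stand, and all three share the limit of > 100000 nM in this assay, at which 3 of the 3 values shown sit, as their only reading.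

The next structure is compound 4 `CNc1ncnc2c1c(-c1ccccc1)cn2[C@@H]1O[C@H](CO)[C@@H](O)[C@H]1O` with phenyl in place of furan-3-yl on an aromatic carbon. Phenyl is not new here, since compound 1 and compound 2 carry it and neither leaves the limit. For the measured compounds named here, the one measured step is a step that the two limits leave unreadable from compound 1 to compound 2 and it lies elsewhere on the molecule, so it offers no size to carry over. With no readable step to go on, no change beyond the usual scatter is expected in this assay and the expected move is a number no higher from compound 3 to compound 4 (the limit leaves the size open) in no clear direction. For compound 4 the estimated value is 100000 nM with an expected range from 30000 nM to 150000 nM and the result may again be only a limit.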

Compound 4, half-maximal inhibitory concentration: > 100000 nM
Compound 4: only a limit was reported (the forecaster's own chance of this, stated with the estimate: 75%); the middle value sits exactly at the limit.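

In this assay compound 4 gives > 100000 nM, which is a limit of the assay and not a number. For the compounds shown here, no step from compound 1, compound 2 or compound 3 to compound 4 can be read. The compounds shown leave open how far any of these changes moves the inhibition, because every reading stands at one point: the limit of > 100000 nM in this assay, at which 4 of the 4 values shown sit.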